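A few compounds are considered here, and "the series" means these few. Any claim that something is new, unique, unknown or untested is made for them only; others in the source may bear on it.

Going by the values given here, compound 1 `FC(F)(F)c1cccc(NC(=S)Nc2ccc(Cl)cc2)c1` stands lowest of the three numbers known here. In an ADME assay on MT4 cells (Homo sapiens) for cytotoxicity (on this read-out lower numbers stand for higher toxicity in this test and higher numbers for lower toxicity in this test), compound 1 gives 6800 nM. Compound 2 `FC(F)(F)c1cccc(NC(=S)NCc2ccco2)c1` gives 43000 nM and compound 3 `FC(F)(F)c1cccc(NC(=S)Nc2ccccc2Br)c1` gives 36000 nM. The steps of a 6.3-fold higher number from compound 1 to compound 2 (0.80 log units; beyond the scatter) and a 5.3-fold higher number from compound 1 to compound 3 (0.72 log units; beyond the scatter) both came from changing the group on the amide-type nitrogen of the shared core, while a 1.2-fold lower number from compound 2 to compound 3 (0.08 log units; within the scatter) stayed within the scatter. Compound 4 `CCCC[C@H]1CC[C@H](c2ccc(NC(=S)Nc3cccc(C(F)(F)F)c3)cc2)CC1` differs from compound 1 at another place: 4-butylcyclohexyl in place of chloro on an aromatic carbon. Among the compounds with values here, no measured step touches this aromatic carbon, so the numbers give no direction, and the expectation rests on compound 1 alone. Compound 4 is therefore estimated at 7000 nM, between 2000 nM and 25000 nM. The expected step of a 1.0-fold higher number from compound 1 to compound 4 (0.01 log units; within the scatter) lies within the scatter.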

Compound 4, half-maximal cytotoxic concentration: 22000 nM
Compound 4: middle estimate off by 3.1-fold (0.50 log units), on the low side, within the range that was stated.
By their numbers in this assay, from the lowest: compound 1; then compounds 4, 3 and 2 (each within the scatter of the next).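

Going by these compounds alone, the earlier steps all changed the group on the amide-type nitrogen, so this is the first sign that the aromatic carbon also matters in this assay and the change there gives a 3.2-fold higher number from compound 1 to compound 4 (0.51 log units; beyond the scatter) with 4-butylcyclohexyl in place of chloro. Here, a group of 10 heavy atoms replacing a single chlorine goes with a higher number, which means lower toxicity in this test. No measurement on hand explains this step. As far as these compounds go, whether the ring or the butyl chain matters more remains open. So does the outcome with a methyl, an amine or a carboxylic acid on this carbon.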